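Changing the ester on the shared core: toward compound 3

The source may report more compounds than this note shows. Statements on the series, on what has been measured and on what is new or still open speak of the compounds shown alone.

In a functional assay on MCF7 cells (Homo sapiens) for antiproliferative activity, read by MTT assay, with a stated time of 72 h (a lower number here means a stronger inhibitor, a higher number a weaker inhibitor), compound 1 `CC1=CC[C@H]2[C@H](CC[C@]2(C)O)C(C)(C)[C@@H]1CC[C@H]1[C@]2(C)CC[C@H](OC(=O)CCC(=O)O)C(C)(C)O[C@H]2CC[C@@]1(C)O` gives > 50000 nM as a limit and not a number. Among the measured compounds shown here, compound 2 `CC1=CC[C@H]2[C@H](CC[C@]2(C)O)C(C)(C)[C@@H]1CC[C@H]1[C@]2(C)CC[C@H](OC(=O)c3ccccc3F)C(C)(C)O[C@H]2CC[C@@]1(C)O` gives 11300 nM in this assay and holds the only true number so far. For the measured compounds named here, the single measured step, with 2-fluorophenyl in place of 2-carboxyethyl on a carbonyl carbon, is an at least 4.4-fold lower number from compound 1 to compound 2 (0.64 log units; beyond the scatter) and rests on the limit of > 50000 nM in this assay, at which 1 of the 2 values shown sits, at its start. Compound 3 `CC1=CC[C@H]2[C@H](CC[C@]2(C)O)C(C)(C)[C@@H]1CC[C@H]1[C@]2(C)CC[C@H](OC(=O)c3ccc([N+](=O)[O-])o3)C(C)(C)O[C@H]2CC[C@@]1(C)O` carries 5-nitrofuran-2-yl in place of 2-fluorophenyl on a carbonyl carbon, and 5-nitrofuran-2-yl in place of 2-fluorophenyl on a carbonyl carbon gives the change in full. The measured step bears on this only loosely, since it shows that a change at this carbonyl carbon can shift the read-out but involves no nitrofuran. Compound 2 at 11300 nM is therefore the anchor, and no step beyond the scatter is expected in this assay in either direction. The expected change is a 1.1-fold lower number from compound 2 to compound 3 (0.05 log units; within the scatter) and stays small. For compound 3 the estimate is 10000 nM with an expected range from 4000 nM to 30000 nM in this assay.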

Compound 3, half-maximal inhibitory concentration: 21300 nM
The estimate for compound 3 lay 2.1-fold (0.33 log units) below the measured number; measured number inside the range.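

In this assay, 5-nitrofuran-2-yl in place of 2-fluorophenyl on this carbonyl carbon gives a 1.9-fold higher number from compound 2 to compound 3 (0.28 log units; within the scatter), so the position does not separate these two aromatic groups, although the entering group has a five-membered ring with a hetero atom and hydrogen-bond acceptors that the leaving group lacks. A second aromatic group also stands against 2-carboxyethyl, with an at least 2.3-fold lower number from compound 1 to compound 3 (0.37 log units; beyond the scatter), so the lower number seen with 2-fluorophenyl does not depend on that group alone. This step starts from a limit and not a number, the one held by compound 1: the limit of > 50000 nM in this assay, at which 1 of the 3 values shown sits.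

Open, going by these compounds, is whether an aromatic ring is needed here at all, which a plain longer alkyl chain on the carbonyl carbon would test. Also open, on these data alone, is how an amine on the acyl group, or a carboxylic acid on an aromatic ring, would read.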